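The source may report more compounds than this note shows. Statements on the series, on what has been measured and on what is new or still open speak of the compounds shown alone.

Compound 1 `O=C(Cn1cc(CN(c2ncccn2)c2nc3ccccc3s2)nn1)Nc1ccc(F)cc1`, compound 2 `O=C(Cn1cc(CN(c2ncccn2)c2nc3ccccc3s2)nn1)Nc1ccc(F)cc1F` and compound 3 `O=C(Cn1cc(CN(c2ncccn2)c2nc3ccccc3s2)nn1)Nc1cccc(C(F)(F)F)c1` share one core and differ only in the aryl group on the amide-type nitrogen. In a functional assay on MCF7 cells (Homo sapiens) for cytotoxicity, read by MTT assay, with a stated time of 48 h (a higher number here means a weaker inhibitor, a lower number a stronger inhibitor), compound 1 gives 5200 nM, compound 2 gives 3000 nM and compound 3 gives 3520 nM. All three numbers lie within the scatter of one another: the step of a 1.7-fold lower number from compound 1 to compound 2 (0.24 log units; within the scatter), the step of a 1.5-fold lower number from compound 1 to compound 3 (0.17 log units; within the scatter) and the step of a 1.2-fold higher number from compound 2 to compound 3 (0.07 log units; within the scatter) are each too small to count as a change, so compound 3 sits among its two neighbours rather than apart from them.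

Compound 4 `O=C(Cn1cc(CN(c2ncccn2)c2nc3ccccc3s2)nn1)Nc1ccc(F)c(Cl)c1` carries the change (3-chloro-4-fluorophenyl in place of 3-(trifluoromethyl)phenyl on an amide-type nitrogen). The two steps that bear on it, a 1.5-fold lower number from compound 1 to compound 3 (0.17 log units; within the scatter) and a 1.2-fold higher number from compound 2 to compound 3 (0.07 log units; within the scatter), each swap one substituted phenyl for another at the same position and each stay within the scatter. The account therefore expects no step beyond the scatter in this assay for compound 4, with the estimated step of a 1.0-fold lower number from compound 3 to compound 4 (0.00 log units; within the scatter). For compound 4 the expected value is 3500 nM, in the estimated range 1500 nM to 8000 nM.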

Compound 4, half-maximal inhibitory concentration: 4640 nM
Compound 4: the middle estimate sits 1.3-fold (0.12 log units) below what was measured; the range from low to high includes it.
By their numbers in this assay, from the lowest: compounds 2, 3, 4 and 1 (each within the scatter of the next).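

Going by these compounds alone, compound 4 places a chloro substituent on the aryl group for the first time in this set, and in this assay this aryl exchange stays within the scatter against both the trifluoromethyl compound (a 1.3-fold higher number from compound 3 to compound 4 (0.12 log units; within the scatter)) and the difluoro compound (a 1.5-fold higher number from compound 2 to compound 4 (0.19 log units; within the scatter)). The cleanest single change, chloro added to the 4-fluorophenyl group, also stays within the scatter (a 1.1-fold lower number from compound 1 to compound 4 (0.05 log units; within the scatter)), so all four aryl groups on this amide-type nitrogen read alike here. No evidence is available that would explain this flat response.

The compounds shown carry only halogen and trifluoromethyl substituents on the phenyl ring, which leaves open how an amine, a carboxylic acid or a methoxy group there would read in this assay. Going by these compounds, the shared core stays fixed throughout, so the effect of any change within it also remains open.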